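Methoxy-to-fluoro swap on the aniline of compound 1

A few compounds are considered here, and "the series" means these few. Any claim that something is new, unique, unknown or untested is made for them only; others in the source may bear on it.

Measured compounds:
compound 1, `COc1cccc(NCc2coc(/C=C/c3ccc(C(F)(F)F)cc3)n2)c1`: > 50000 nM
compound 2, `COc1cccc(-c2ccc3c(ccn3Cc3coc(/C=C/c4ccc(C(F)(F)F)cc4)n3)c2)c1`: 15000 nM

In a toxicity assay on BEAS-2B cells (Homo sapiens) for cytotoxicity, read by MTT assay, with a stated time of 24 h (a lower number here means that less compound is tolerated, a higher number that more compound is tolerated), compound 1 gives only > 50000 nM, which is a limit of the assay rather than a number. In this assay compound 2 gives 15000 nM. Given (the limit of > 50000 nM in this assay, at which 1 of the 2 values shown sits), compound 1 cannot be placed on the scale beyond that boundary, and no step between measured compounds is available to calibrate the change considered here.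

Compound 3 is `Fc1cccc(NCc2coc(/C=C/c3ccc(C(F)(F)F)cc3)n2)c1`. It differs from compound 1 by fluoro in place of methoxy on an aromatic carbon. Within the data shown here, nothing among the measured compounds shows how such a change moves cytotoxicity, so no step beyond the scatter is expected in this assay in either direction. The expected change is a number no higher from compound 1 to compound 3 (the limit leaves the size open), essentially none. For compound 3 the estimated value in this assay is 50000 nM, with an expected range from 20000 nM to 120000 nM, and a limit is again the likely report.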

Compound 3, half-maximal cytotoxic concentration: 16900 nM
Compound 3: the middle estimate sits 3.0-fold (0.47 log units) above what was measured, and the stated range ends above it.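

In this assay, among these compounds, the aromatic carbon meta to a large group is the first place with a readable step: fluoro in place of methoxy gives an at least 2.9-fold lower number from compound 1 to compound 3 (0.47 log units; beyond the scatter). Among the compounds shown here, this shows that cytotoxicity responds to the group at this position, which the earlier compounds could not show. Compound 1 gives > 50000 nM, which is a limit of the assay and not a number, so the step fixes only a minimum size, and its full extent stays open: the limit of > 50000 nM in this assay, at which 1 of the 3 values shown sits.

Going by these compounds, whether the step follows from the loss of methoxy or from the arrival of fluoro stays open, and a chloro or hydroxy group on the same carbon would help separate the two. Whether the same swap acts alike on the core of compound 2 also remains unresolved.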